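Amine substituent variation on the carboxylic acid series

The source may report more compounds than this note shows. Statements on the series, on what has been measured and on what is new or still open speak of the compounds shown alone.

Measured compounds:
compound 1 `Cc1cc(CN(C)C(CC(=O)O)c2ccc(Cl)cc2)ccc1OCCn1c(=O)ccn(C)c1=O` — 1300 nM
compound 2 `CCCN(Cc1ccc(OCCn2c(=O)ccn(C)c2=O)c(C)c1)C(CC(=O)O)c1ccc(Cl)cc1` — 123 nM
compound 3 `Cc1cc(CN(CC2CC2)C(CC(=O)O)c2ccc(Cl)cc2)ccc1OCCn1c(=O)ccn(C)c1=O` — 91 nM

All three were tested in an assay on CHO cells for displacement of a labelled ligand from C-X-C chemokine receptor type 3 (Homo sapiens), with a stated time of 60 min; on this read-out lower numbers stand for stronger inhibition and higher numbers for weaker inhibition. Compound 3 gives the lowest number of the three; its gap to compound 2 is within the scatter, while compound 1 sits far higher.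

Compound 4 `Cc1cc(CN(C2CCC2)C(CC(=O)O)c2ccc(Cl)cc2)ccc1OCCn1c(=O)ccn(C)c1=O` differs from compound 3 by cyclobutyl in place of cyclopropylmethyl on an amine nitrogen. Among the measured compounds shown here, no measured step rearranges the same atoms in this way. For the measured compounds named here, the steps that bear on it are a 14-fold lower number from compound 1 to compound 3 (1.15 log units; beyond the scatter) and an 11-fold lower number from compound 1 to compound 2 (1.02 log units; beyond the scatter), which show that enlarging the group on this nitrogen beyond methyl gives a large gain, and a 1.4-fold lower number from compound 2 to compound 3 (0.13 log units; within the scatter), which shows that the shape of a four-carbon group matters little. Compound 4 keeps a four-carbon group, so the expected step of a 1.6-fold higher number from compound 3 to compound 4 (0.22 log units; within the scatter) is small. Compound 4 is estimated at 150 nM, range 50 nM to 500 nM.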

Compound 4, half-maximal inhibitory concentration in the C-X-C chemokine receptor type 3 assay: 95 nM
Beside the measured number, compound 4's estimate is 1.6-fold (0.20 log units) above it; low and high end bracket the measured number.
By their numbers in the C-X-C chemokine receptor type 3 assay, from the lowest: compounds 3, 4 and 2 (each within the scatter of the next); then compound 1.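

In the C-X-C chemokine receptor type 3 assay, compound 4, with cyclobutyl on an amine nitrogen, gives 95 nM and matches the two open-chain-attached groups: cyclopropylmethyl gives way to it with a 1.0-fold higher number from compound 3 to compound 4 (0.02 log units; within the scatter), and propyl with a 1.3-fold lower number from compound 2 to compound 4 (0.11 log units; within the scatter), so these three groups cannot be ordered, while replacing methyl still gives a 14-fold lower number from compound 1 to compound 4 (1.14 log units; beyond the scatter). In a physicochemical assay for solubility, at pH 1.1 (a lower number here means a less soluble compound, a higher number a more soluble compound), compound 3 gives 3000000 nM and compound 4 gives 3000000 nM, and the same exchange gives no change at the digits printed from compound 3 to compound 4 (within the scatter). No evidence on hand explains this flat response among the three groups.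

From the compounds shown here alone, whether larger groups such as cyclohexyl or benzyl hold this level stays open. So does the effect of a hydroxyl or a second amine on the group at this nitrogen.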